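The source may report more compounds than this note shows. Statements on the series, on what has been measured and on what is new or still open speak of the compounds shown alone.

Of the compounds shown here, three built on a shared core have been tested in a functional assay on HEK293 cells with Glucose-dependent insulinotropic receptor (Homo sapiens) as the target, read by HTRF and cAMP accumulation, with a stated time of 30 min; on this read-out higher numbers stand for larger maximal responses and lower numbers for smaller maximal responses. Compound 1 `CC1(C)C[C@]2(CC[C@H](c3nc(COc4ccc(-n5cnnn5)cc4)cs3)CC2)CO1` gives 79% in this assay. Compound 2 `CC(O[C@H]1CC[C@]2(CC1)COC(C)(C)C2)c1nc(-c2ccc(S(C)(=O)=O)c(F)c2)no1` gives 109%. Compound 3 `Cc1c(Nc2ccc(S(C)(=O)=O)cc2F)ncnc1O[C@H]1CC[C@]2(CC1)COC(C)(C)C2` reaches 91%. Among these three numbers compound 3 stands second highest: compound 1 lies below it by more than the usual scatter, and compound 2 lies above it by more than the usual scatter.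

Compound 4 `Cc1c(Nc2ccc(C(=O)N(C)C)cc2F)ncnc1O[C@H]1CC[C@]2(CC1)COC(C)(C)C2` has not yet been measured. It differs from compound 3 in one place only: dimethylcarbamoyl in place of methylsulfonyl on an aromatic carbon. Among the compounds with values here, no pair of measured compounds shows this exchange, so there is no direct precedent among the measured compounds for how it behaves in this assay. The step expected in this assay is small, likely within the usual scatter and, if anything, slightly downward: a number 6 percentage points lower from compound 3 to compound 4 (within the scatter). Compound 4 is therefore estimated to give 85% in this assay, with a range from 65% to 105%.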

Compound 4, intrinsic activity: the largest response reached, in percent of the reference agonist's: 101%
Compound 4: the middle estimate sits 16 percentage points below what was measured, and the stated range covers the measured number.
By their numbers in this assay, from the lowest: compound 1; then compounds 3, 4 and 2 (each within the scatter of the next, the first and the last beyond it).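

In this assay, putting dimethylcarbamoyl in place of methylsulfonyl gives a number 10 percentage points higher from compound 3 to compound 4 (within the scatter), so the two compounds cannot be told apart on this read-out. Within the data shown here, this is the first sign that, on an aromatic carbon meta to a fluoro group and para to a large group, the maximal response does not depend on methylsulfonyl: an amide-type group with a different atom make-up serves as well in this pair. No measurement at hand accounts for why the two groups give such similar responses.

From the compounds shown here alone, it remains open whether a primary amine, a carboxylic acid or a nitrile at this position would keep the response at the same level. Going by these compounds, it is also open whether the same exchange would behave alike in compound 2, which carries methylsulfonyl on a different scaffold.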